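Fused-ring nitrile series: exchange at the amine-bearing ring carbon

The source may hold more compounds than are shown below. What is called first, only, known or untested is meant among the compounds shown, and "the series" means these compounds.

Measured so far:
compound 1, `N#CC1=C(NC(=S)Nc2ccccc2)N(c2ccc(S(N)(=O)=O)cc2)C2=C(C(=O)CCC2)C1c1ccc(Cl)cc1Cl`: 50%
compound 2, `N#CC1=C(NC(=S)Nc2ccc(Br)cc2)N(c2ccc(S(N)(=O)=O)cc2)C2=C(C(=O)CCC2)C1c1ccc(Cl)cc1Cl`: 50%
compound 3, `N#CC1=C(NC(=O)CCC(=O)O)N(c2ccc(S(N)(=O)=O)cc2)C2=C(C(=O)CCC2)C1c1ccc(Cl)cc1Cl`: 35%

In a functional assay on Ehrlich cells (Mus musculus) for cytotoxicity, read by trypan blue exclusion, with a stated time of 2 h, tested at 25 ug/mL (on this read-out higher numbers stand for a stronger effect at the one concentration tested and lower numbers for a weaker effect), compound 1 gives 50%. It stands level with compound 2 at the digits shown, and the two together are the highest of the three numbers; compound 3 is the only one set apart, below them. The step of no change at the digits printed from compound 1 to compound 2 (within the scatter) shows that the bromo on the aromatic ring leaves the read-out where it was. The steps of a number 15 percentage points lower from compound 1 to compound 3 (beyond the scatter) and a number 15 percentage points lower from compound 2 to compound 3 (beyond the scatter) are the two that bear on the new compound: in each the arylthioureido group on the amine nitrogen gives way to a short open chain carrying three oxygens, and in each the number drops by the same modest amount.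

Compound 4, `N#CC1=C(N2C(=O)CCC2=O)N(c2ccc(S(N)(=O)=O)cc2)C2=C(C(=O)CCC2)C1c1ccc(Cl)cc1Cl`, is not yet measured. Against compound 1 the change is a group of 7 heavy atoms (4 carbon, 1 nitrogen, 2 oxygen; one five-membered non-aromatic ring with 1 hetero atom) in place of a group of 10 heavy atoms (7 carbon, 2 nitrogen, 1 sulfur; one six-membered aromatic ring of carbon only), on a double-bonded ring carbon. As in compound 3, the aromatic ring and both donors of the group are lost; what enters is a small cyclic imide rather than the open chain. Among the measured compounds shown here, with only two informative steps, both pointing the same way, a drop of similar size is expected, a number 13 percentage points lower from compound 1 to compound 4 (beyond the scatter). Compound 4 is therefore estimated at 37%, with a range of 25% to 50%.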

Compound 4, a percentage reported as activity, at one concentration (the size of the read-out at that concentration, not a potency): 50%
Compound 4: the middle estimate sits 13 percentage points below what was measured; the measured number falls inside the stated range.
By their numbers in this assay, from the lowest: compound 3; then compounds 1, 2 and 4 (each within the scatter of the next).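

In this assay, the change on this double-bonded ring carbon from the arylthioureido groups to 2,5-dioxopyrrolidin-1-yl gives no change at the digits printed from compound 1 to compound 4 (within the scatter) and no change at the digits printed from compound 2 to compound 4 (within the scatter), so within these compounds neither the six-membered aromatic ring of the leaving group nor its hydrogen-bond donors are required to hold the read-out. Compound 3 and compound 4 both lack that ring. Only compound 3 has the lower number. The direct exchange of ((2-carboxyethyl)carbonyl)amino for 2,5-dioxopyrrolidin-1-yl gives a number 15 percentage points higher from compound 3 to compound 4 (beyond the scatter), which shows that the identity of the entering group matters at this position even when the aromatic ring is absent. No data are available to explain the difference between these two groups.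

The compounds shown leave open whether the lower number of compound 3 goes with its carboxylic acid or with its open chain, a question that a simple amide lacking the carboxylic acid, or the corresponding methyl ester, would address. They also leave open how a free amine or a longer chain at this position would read in this assay and whether the level shared by compounds 1, 2 and 4 would persist across a range of concentrations.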